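A few compounds are considered here, and "the series" means these few. Any claim that something is new, unique, unknown or untested is made for them only; others in the source may bear on it.

Series values in a functional assay on MCF7 cells (Homo sapiens) for antiproliferative activity, read by MTT assay, with a stated time of 48 h; a higher number here means a weaker inhibitor, a lower number a stronger inhibitor:
- compound 1 `COc1cc(/C=C/C(C)=O)ccc1OCc1cn(-c2ccccc2OC)nn1`: 29100 nM
- compound 2 `COc1cc(/C=C/C(C)=O)ccc1OCc1cn(-c2ccc(NC(=O)c3ccccc3)cc2)nn1`: 86700 nM
- compound 3 `CCOC(=O)c1ccc(-n2cc(COc3ccc(/C=C/C(C)=O)cc3OC)nn2)cc1`: > 100000 nM (a limit of the assay, not a number)

Compound 1 holds the lower of the two numeric values, and the gap to compound 2, which gives 86700 nM, lies beyond the scatter. Compound 4 `COc1cc(/C=C/C(C)=O)ccc1OCc1cn(-c2ccccc2O)nn1` follows from compound 1 by hydrogen in place of methyl on an oxygen on an aromatic ring, turning 2-methoxyphenyl into 2-hydroxyphenyl. For the measured compounds named here, the only measured step, an at least 1.1-fold higher number from compound 2 to compound 3 (0.06 log units; that floor lies within the scatter), is ethoxycarbonyl in place of benzamido on an aromatic carbon. It involves different groups and gives no direct guide, so no shift beyond the scatter is expected in this assay. The expected step is a 1.2-fold higher number from compound 1 to compound 4 (0.08 log units; within the scatter). For compound 4 the estimated value is 35000 nM, with an expected range of 12000 nM to 95000 nM.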

Compound 4, half-maximal inhibitory concentration: > 100000 nM
Compound 4: no number, only a limit; the forecaster's own chance of this, stated with the estimate: 15%; at least 2.8-fold (0.45 log units) between middle value and limit.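

In this assay, replacing methoxy with hydroxy on the 2-methoxyphenyl group gives a change beyond the scatter, with an at least 3.4-fold higher number from compound 1 to compound 4 (0.53 log units; beyond the scatter). For the compounds shown here, this is the first step read at this position, and it shows that removing this one methyl is enough to lose the measurable activity of compound 1. Compound 4 gives > 100000 nM, a limit and not a number, so the step is only a floor, and this limit recurs in the series: the limit of > 100000 nM in this assay, at which 2 of the 4 values shown sit.

From the compounds shown here alone, the true size of the step remains open. Also open, going by these compounds, is how an amine or a longer chain such as ethoxy on this oxygen-bearing aromatic carbon would read.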